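The source may report more compounds than this note shows. Statements on the series, on what has been measured and on what is new or still open speak of the compounds shown alone.

Measured so far:
- compound 1, `CC(=O)Nc1ccc(S(=O)(=O)NNc2ccc(C(F)(F)F)cc2)cc1`: 181 nM
- compound 2, `CC(=O)Nc1ccc(S(=O)(=O)NNc2ccc(F)c(Cl)c2)cc1`: 2590 nM
- compound 3, `O=S(=O)(NNc1ccc(Br)cc1)c1ccccc1`: 128 nM

All three numbers come from an assay on HeLa cells for inhibition of Indoleamine 2,3-dioxygenase 1 (Homo sapiens), read by spectrophotometry, with a stated time of 24 h; a higher number here means that more compound is needed for the effect, a lower number that less compound is needed. Compound 3 gives the lowest of the three numbers in this assay. Its nearest neighbour is compound 1, whose number is higher by an amount within the scatter, so the two cannot be ordered. Compound 2 sits far higher, beyond the scatter; as the two pairs differ in more than one place, the numbers alone are all that can be said of them.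

Compound 4, `O=C(O)c1ccc(S(=O)(=O)NNc2ccc(Br)cc2)cc1`, is not yet measured. It differs from compound 3 by one change: carboxy in place of hydrogen on an aromatic carbon. Going by the values given here, no measured pair isolates this change, so the size of the step is a guess. A modest move toward a higher number is expected, a 3.1-fold higher number from compound 3 to compound 4 (0.49 log units; beyond the scatter), with a wide band around it. Compound 4 is therefore estimated at 400 nM, from 100 nM to 1600 nM.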

Compound 4, half-maximal effective concentration: 172 nM
For compound 4 the middle estimate is 2.3-fold (0.37 log units) above the measured one; measured number inside the range.
By their numbers in this assay, from the lowest: compounds 3, 4 and 1 (each within the scatter of the next); then compound 2.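

In this assay carboxy in place of hydrogen on an aromatic carbon gives a 1.3-fold higher number from compound 3 to compound 4 (0.13 log units; within the scatter) and so no readable change. Going by these compounds alone, this is the first one-place comparison: para to a large group, the ring takes a carboxy group, with its 3 heavy atoms, one hydrogen-bond donor and one hydrogen-bond acceptor, without a shift beyond the scatter. Nothing available explains why the number holds at this place.

Other groups at this place remain open, such as an amine, a methyl ester or a primary amide, and a single substituent cannot show how far this result extends. Also open, on these data alone, is whether carboxy gives a similarly small step when the other aromatic ring carries trifluoromethyl rather than bromine.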